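The source may hold more compounds than are shown below. What is called first, only, known or untested is meant among the compounds shown, and "the series" means these compounds.

In a functional assay on HCT-116 cells (Homo sapiens) for inhibition, read by CCK-8 assay, with a stated time of 48 h (on this read-out lower numbers stand for stronger inhibition and higher numbers for weaker inhibition), two compounds have been read so far. Compound 1 `COc1cc(-c2cc3nccc(-c4c[nH]c5ccccc45)n3n2)cc(OC)c1OC` gives > 10000 nM as its result, and this is a limit of the assay, not a number. For the measured compounds named here, compound 2 `COc1cc(-c2ccnc3cc(-c4ccc(C)c(C)c4)nn23)cc(OC)c1OC` gives 261 nM as its result, the only actual number available so far. Compound 3 `COc1cc(-c2ccnc3cc(-c4ccc(C(F)(F)F)cc4)nn23)cc(OC)c1OC` has not yet been measured. It departs from compound 2 at one place, where 4-(trifluoromethyl)phenyl stands in place of 3,4-dimethylphenyl on an aromatic carbon of a five-membered aromatic ring with 2 nitrogen, part of a fused or bridged system of two rings. Counted in full, the change reads 4-(trifluoromethyl)phenyl in place of 3,4-dimethylphenyl on an aromatic carbon and nothing else differs. Going by the values given here, no measured step in this assay covers this exchange, and the expectation rests on compound 2 at 261 nM alone. A moderate weakening somewhat beyond the scatter is expected, though the direction is uncertain, and the estimated change is a 2.7-fold higher number from compound 2 to compound 3 (0.43 log units; beyond the scatter) on this reading. Compound 3 is expected at 700 nM with a likely range from 150 nM to 4000 nM once it is tested in this assay.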

Compound 3, half-maximal inhibitory concentration: 1860 nM
The estimate for compound 3 lay 2.7-fold (0.42 log units) below the measured number; low and high end bracket the measured number.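

In this assay, the exchange of 3,4-dimethylphenyl for 4-(trifluoromethyl)phenyl on this aromatic carbon of the five-membered ring gives a 7.1-fold higher number from compound 2 to compound 3 (0.85 log units; beyond the scatter). For the compounds shown here, this is the first comparison in the set that differs in one place only, and it shows that the position is not indifferent to what the phenyl ring carries, even though both groups keep one six-membered aromatic ring of carbon only. Compound 3 still gives a real number, whereas compound 1 alone sits at a limit, which is not a number: the limit of > 10000 nM in this assay, at which 1 of the 3 values shown sits.

A single step cannot separate the two things that change together here, the loss of the two methyl groups and the entry of the trifluoromethyl group, so it remains unclear which of them accounts for the weaker result. On these data alone, it is also open how a single methyl group, an amine, a nitrile or a carboxylic acid on that phenyl ring would compare with 3,4-dimethylphenyl at this position.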